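This account rests on a few compounds, and the source may have more. Where it says the series, first, only, none or still open, it means among the compounds named here.

Values in an ADME assay on microsomes from liver (Homo sapiens) for metabolic stability; on this read-out higher numbers stand for fast clearance and lower numbers for slow clearance:
- compound 1 `O=C(N1CCC(c2ccccc2)CC1)N(c1ncccc1Cl)[C@@H]1CCCNC1`: < 9.3 mL.min-1.g-1 (a limit)
- compound 2 `Cn1ccc2ccnc(N(C(=O)N3CCC(c4ccccc4)CC3)[C@@H]3CCCNC3)c21`: 11.8 mL.min-1.g-1

Compound 1 sits at the limit of < 9.3 mL.min-1.g-1 in this assay, at which 1 of the 2 values shown sits; this is a limit, not a number. Compound 3 `O=C(N1CCC(c2cnn3cccnc23)CC1)N(c1ncccc1Cl)[C@@H]1CCCNC1` differs from compound 1 in one place: a group of 9 heavy atoms (6 carbon, 3 nitrogen; one five-membered aromatic ring with 2 hetero atoms, one six-membered aromatic ring with 2 hetero atoms) in place of a group of 6 heavy atoms (6 carbon; one six-membered aromatic ring of carbon only), on a saturated ring carbon.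

Within the data shown here, the only measured step is an at least 1.2-fold higher number from compound 1 to compound 2 (0.10 log units; that floor lies within the scatter). It lies on an amide-type nitrogen, not on the saturated ring carbon changed here, and it offers only weak guidance. No change beyond the scatter is expected in this assay, and the expected step is a step that the limit leaves unreadable from compound 1 to compound 3. For compound 3 the estimated value is 8 mL.min-1.g-1, with an expected range of 4 mL.min-1.g-1 to 16 mL.min-1.g-1.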

Compound 3, intrinsic clearance in microsomes: < 8 mL.min-1.g-1
Compound 3: a limit, no number; the forecaster's own chance of this, stated with the estimate: 60%; the middle value sits exactly at the limit.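

No step can be read from compound 1 to compound 3 in this assay, since each compound carries a limit and not a number. The compounds shown leave open how replacing phenyl on the saturated ring carbon alters clearance.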